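The source may report more compounds than this note shows. Statements on the series, on what has been measured and on what is new or still open speak of the compounds shown alone.

Of the compounds shown here, three sharing the core have been measured in an ADME assay on microsomes from liver (Rattus norvegicus) for metabolic stability, read by HPLC, with a stated time of 10 min, tested at 3 uM; on this read-out lower numbers stand for a less stable compound and higher numbers for a more stable compound. Compound 1 `COC[C@H](C1CC1)n1cc(Cl)nc(Nc2cc(C)c(OC)nc2C)c1=O` gives 24%, compound 2 `COC[C@@H](C)n1cc(Cl)nc(Nc2cc(C)c(OC)nc2C)c1=O` gives 8%, and compound 3 `COC[C@H](C1CC1)n1cc(Cl)nc(Nc2cc(C#N)c(OC(F)F)nc2C)c1=O` gives 70%, the highest of the three numbers and clear of the other two beyond the scatter.

Compound 4 `COC[C@@H](C1CC1)n1cc(Cl)nc(Nc2cc(C#N)c(OC(F)F)nc2C)c1=O` departs from compound 3 in one place: the two compounds have the same atoms and bonds and differ only in configuration as drawn: 1 of 1 stereo elements differ; a stereocentre at a saturated chain carbon is drawn S in compound 3 and R in compound 4. Nothing leaves and nothing enters.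

Within the data shown here, only one measured step bears on this, and only loosely. It is a number 16 percentage points lower from compound 1 to compound 2 (beyond the scatter), with 1-(methoxymethyl)ethyl in place of 1-cyclopropyl-2-methoxyethyl on an aromatic nitrogen. This modest step lies beyond the scatter, but it replaces the group rather than altering its configuration, so it offers a rough size and no direction. Among the measured compounds shown here, no pair differing only in configuration has been measured.

A step of similar modest size is therefore expected in this assay. For the measured compounds named here, a lower number seems the likelier direction, with compound 3 at 70% the top of the series so far, although a result within the scatter cannot be excluded. The expected change is a number 15 percentage points lower from compound 3 to compound 4 (beyond the scatter), an estimate with wide uncertainty. In this assay, compound 4 is expected at 55%, with an estimated range of 30% to 80%.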

Compound 4, percent of the compound remaining: 64%
The estimate for compound 4 lay 9 percentage points below the measured number, and the stated range covers the measured number.
By their numbers in this assay, from the lowest: compound 2; then compound 1; then compounds 4 and 3 (each within the scatter of the next).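

In this assay, inverting the stereocentre at the saturated chain carbon gives a number 6 percentage points lower from compound 3 to compound 4 (within the scatter), so with the nitrile and difluoromethoxy substituents in place, this read-out does not separate the S and R forms at this position. Among these compounds, the earlier compounds showed only that replacing the group on the aromatic nitrogen can register, with a number 16 percentage points lower from compound 1 to compound 2 (beyond the scatter), and that step came with the methyl and methoxy substituents in place, so it cannot be set directly against the new one. Among the compounds shown here, the new pair is the first comparison that isolates configuration, and nothing else enters it: the fact that compounds 3 and 4 differ only in the configuration as drawn.

Whether configuration at this carbon is equally silent with the methyl and methoxy substituents of compound 1 remains open, as does which of the two substituent differences between compound 1 and compound 3 accounts for the gap in their printed values. Also open, from the compounds shown here alone, is how this assay would respond to a longer chain in place of the cyclopropyl group, or to a hydroxymethyl group in place of the methoxymethyl arm, in either configuration.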